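This account rests on a few compounds, and the source may have more. Where it says the series, first, only, none or still open, it means among the compounds named here.

The measured compounds:
Compound 1, `COc1cc(OC)c(/C=C(/SCc2ccc(Cl)c(Cl)c2)C(=O)c2ccc(Cl)cc2)c(OC)c1`: 10000 nM
Compound 2, `COc1cc(OC)c(/C=C(\C(=O)c2ccc(Br)cc2)S(=O)(=O)Cc2ccc(Cl)cc2)c(OC)c1`: 25000 nM
Compound 3, `COc1cc(OC)c(/C=C(\C(=O)c2ccc(Cl)cc2)S(=O)(=O)c2ccc(C)cc2)c(OC)c1`: 25000 nM

In a functional assay on DU-145 cells (Homo sapiens) for inhibition, read by trypan blue exclusion, with a stated time of 96 h (on this read-out lower numbers stand for stronger inhibition of growth and higher numbers for weaker inhibition of growth), compound 3 stands level with compound 2 at the digits given, and these two share the highest of the three numbers; compound 1 lies a step below, a 2.5-fold higher number from compound 1 to compound 3 (0.40 log units; beyond the scatter). That one measured step concerns a quite different change and does not bear on the present one.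

Compound 4, `COc1cc(OC)c(/C=C(\C(=O)c2ccc(Br)cc2)S(=O)(=O)c2ccc(C)cc2)c(OC)c1`, differs from compound 3 by bromo in place of chloro on an aromatic carbon. Within the data shown here, no measured pair isolates this change: compound 2 and compound 3 differ in more than one place, though their numbers agree at the digits given. Compound 4 is therefore expected to show no step beyond the scatter, no change at the digits printed from compound 3 to compound 4 (within the scatter). Compound 4 is estimated at 25000 nM, in the range 12000 nM to 50000 nM.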

Compound 4, concentration for 50% growth inhibition: > 100000 nM
Compound 4: a limit, no number (the forecaster's own chance of this, stated with the estimate: 15%); at least 4.0-fold (0.60 log units) between middle value and limit.
By their numbers in this assay, from the lowest: compound 1; then compounds 2 and 3 (each within the scatter of the next). At a limit, above all of these: compound 4.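

In this assay the result for compound 4 is a limit and not a number: the limit of > 100000 nM in this assay, at which 1 of the 4 values shown sits A single halogen exchange on an aromatic carbon is therefore not neutral in this series, with an at least 4.0-fold higher number from compound 3 to compound 4 (0.60 log units; beyond the scatter). Exchanging the group on the sulfonyl sulfur also counts, with an at least 4.0-fold higher number from compound 2 to compound 4 (0.60 log units; beyond the scatter), so the effect of bromo here seems to depend on its sulfonyl partner.

As far as these compounds go, whether fluoro or an amine at this place would behave like chloro or like bromo stays open. So does the size of the step for bromo, since only a limit is available.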